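Notes on a Fluoro to Trifluoromethyl Step

The source may report more compounds than this note shows. Statements on the series, on what has been measured and on what is new or still open speak of the compounds shown alone.

Measured so far in an ADME assay on CHO cells (Cricetulus griseus) for inhibition, read by MTT assay; a higher number here means a weaker inhibitor, a lower number a stronger inhibitor:
compound 1 `CCN(CC)Cc1cc(C)cc(Nc2nc3ccccc3n2Cc2ccc(F)cc2)c1O`: 18700 nM
compound 2 `CCN(CC)Cc1ccc(C)c(Nc2nc3ccccc3n2Cc2ccc(F)cc2)c1O`: a limit, > 50000 nM
compound 3 `CCN(CC)Cc1cc(C)cc(Nc2nc3ccccc3n2Cc2ccc(C(F)(F)F)cc2)c1O`: 29300 nM

Compound 2 has the same atoms as compound 1, joined differently; the difference between the two cores is not broken down here. Compound 1 and compound 3 differ by trifluoromethyl in place of fluoro on an aromatic carbon, and in this assay that change gave a 1.6-fold higher number from compound 1 to compound 3 (0.20 log units; within the scatter). Compound 4 `CCN(CC)Cc1ccc(C)c(Nc2nc3ccccc3n2Cc2ccc(C(F)(F)F)cc2)c1O` is not yet measured; it differs from compound 2 by trifluoromethyl in place of fluoro on an aromatic carbon, the same change at the same place. For compound 2 the assay reports a limit, > 50000 nM, in line with the limit of > 50000 nM in this assay, at which 1 of the 3 values shown sits. With a 1.6-fold higher number from compound 1 to compound 3 (0.20 log units; within the scatter) within the scatter, compound 4 is expected to show a step that the limit leaves unreadable from compound 2 to compound 4 from compound 2. Compound 4 is therefore estimated at 80000 nM, between 40000 nM and 200000 nM, most likely again only a limit.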

Compound 4, half-maximal inhibitory concentration: 33900 nM
The estimate for compound 4 lay 2.4-fold (0.37 log units) above the measured number; measured number below the stated range.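

In this assay, trifluoromethyl in place of fluoro on the core of compound 2 gave an at least 1.4-fold lower number from compound 2 to compound 4 (0.16 log units; that floor lies within the scatter). Compound 2 is reported only as a limit, > 50000 nM; the step therefore has a floor and no exact size. Set beside the step on the core of compound 1, this neither shows that the change carries over from one core to the other nor shows that it behaves differently on each: the same change on two cores in this assay, a 1.6-fold higher number (0.20 log units; within the scatter) from compound 1 to compound 3 and an at least 1.4-fold lower number (0.16 log units; that floor lies within the scatter) from compound 2 to compound 4; the limit leaves it open whether they differ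

Going by these compounds, the actual number for compound 2 remains open. Also open, on these data alone, is how the two cores would compare with a nitrile or a methoxy group at the same place on the benzyl group.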